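A halogen swap where every reading is a limit

The compounds below may be only part of what the source reports. "The series", "measured", "known", "first", "only" and "open" are said of these compounds alone.

Compound 1 (`C=CCOc1ccc2c(=O)c(-c3cc(OC)c(OC)cc3OC)coc2c1`), compound 2 (`COc1cc(OC)c(-c2coc3cc(OCc4ccc(F)cc4)ccc3c2=O)cc1OC`) and compound 3 (`COc1cc(OC)c(-c2coc3cc(OCc4ccc(Br)cc4)ccc3c2=O)cc1OC`) share one core. In a functional assay on HUVEC cells (Homo sapiens) for antiproliferative activity, read by MTT assay, with a stated time of 24 h (a higher number here means a weaker inhibitor, a lower number a stronger inhibitor), compound 1 gives > 10000 nM as a limit and not a number. Compound 2 gives > 10000 nM as a limit as well. As far as these compounds go, compound 3 also gives > 10000 nM as a limit, so its true potency is unknown. Taken together, the limit of > 10000 nM in this assay, at which 3 of the 3 values shown sit, offers no graded reading to build on.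

Compound 4 (`COc1cc(OC)c(-c2coc3cc(OCc4cccc(Cl)c4)ccc3c2=O)cc1OC`) carries 3-chlorophenyl in place of 4-bromophenyl on a saturated chain carbon bound to an oxygen on an aromatic ring. Going by the values given here, two measured steps bear on this change: a step that the two limits leave unreadable from compound 1 to compound 3 and a step that the two limits leave unreadable from compound 2 to compound 3 both have no size to offer. Neither involves a 3-chlorophenyl group, so they give only a weak hint that compound 4 will stay at the limit in this assay as well. The expected change is a step that the limit leaves unreadable from compound 3 to compound 4 with no direction favoured. In this assay compound 4 is estimated at 12000 nM with an expected range from 4000 nM to 40000 nM and quite possibly only a limit again.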

Compound 4, half-maximal inhibitory concentration: > 10000 nM
Compound 4 ended at the assay's limit; the forecaster's own chance of this, stated with the estimate: 85%; the middle value does not contradict the limit.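

No step to compound 4 can be read, from compound 1, compound 2 or compound 3, as all four compounds give only a limit: the limit of > 10000 nM in this assay, at which 4 of the 4 values shown sit.

The compounds shown leave open how strongly each truly inhibits, and whether the vinyl, 4-fluorophenyl, 4-bromophenyl and 3-chlorophenyl groups differ at all.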